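The compounds below may be only part of what the source reports. "The series", "measured", "known", "first", "only" and "open" are said of these compounds alone.

In a functional assay on KOPN-8 cells (Homo sapiens) for antiproliferative activity, with a stated time of 72 h (a lower number here means that less compound is needed, a higher number that more compound is needed for the effect), compound 1 `COC(=O)c1cc(=O)c2c(OC)cc(OC)cc2[nH]1` reaches only the assay limit, reported as > 34400 nM, so no number is known for it. Compound 2 `COc1ccc(-c2cc(=O)c3c(OC)cc(OC)cc3n2S(=O)(=O)c2ccc(C#N)cc2)cc1` likewise gives only a limit in this assay, namely > 17200 nM. Both values sit at a limit, as the limit of > 17200 nM in this assay, at which 1 of the 2 values shown sits, and the limit of > 34400 nM in this assay, at which 1 of the 2 values shown sits, show, so compound 2 stands among the compounds for which this assay returned no measurable potency. Compound 3 `COc1ccc(-c2cc(=O)c3c(OC)cc(OC)cc3n2S(=O)(=O)c2ccc(Br)s2)cc1` differs from compound 2 in one place: 5-bromothiophen-2-yl in place of 4-cyanophenyl on a sulfonyl sulfur. Going by the values given here, no measured pair in this set shares that change, so its size is unknown here. Since compound 2 gave only a limit, compound 3 is expected to stay weak, and the step that the limit leaves unreadable from compound 2 to compound 3 is expected to be no larger than the usual scatter. Compound 3 is therefore estimated at 20000 nM, with a likely range from 5000 nM to 60000 nM, and a limit rather than a number remains the more probable outcome.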

Compound 3, half-maximal effective concentration: > 48200 nM
Compound 3 was reported as a limit (the forecaster's own chance of this, stated with the estimate: 65%); middle value at least 2.4-fold (0.38 log units) away from the limit.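

In this assay, compound 2 and compound 3 both gave only limits, so the step between them, 5-bromothiophen-2-yl in place of 4-cyanophenyl on a sulfonyl sulfur, cannot be read. The compounds shown leave open whether any group at that place gives a measurable potency in this assay.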